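Benzoxazole amide series: liver microsome clearance notes

A few compounds are considered here, and "the series" means these few. Any claim that something is new, unique, unknown or untested is made for them only; others in the source may bear on it.

Measured so far in an ADME assay on microsomes from liver (Homo sapiens) for metabolic stability, read by LC-MS, using NADPH, with a stated time of 45 min, tested at 0.5 uM; a higher number here means faster removal of the compound, a lower number slower removal:
- compound 1, `O=C(CCNc1nc2cc(Cl)ccc2o1)N1CCCC1`: 2.3 mL/min/g
- compound 2, `CN(C(=O)CCSc1nc2cc(Cl)ccc2o1)C1CCS(=O)(=O)C1`: 1.5 mL/min/g
- compound 3, `O=C(CCSc1nc2ccncc2o1)N1CCCC1`: 0.9 mL/min/g

Compound 1 gives the highest of the three numbers in this assay, but compound 2 sits within the usual scatter of it, so these two cannot be told apart on the data at hand. Compound 3 lies beyond the scatter below compound 1. Going by the values given here, none of the three pairs differs in a single place, so no step between measured compounds can be read off, and the three structures differ from one another in several respects at once.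

The next compound, compound 4, `CN(CCC(=O)N1CCCC1)c1nc2cc(Cl)ccc2o1`, differs from compound 1 in one place: methyl in place of hydrogen on a nitrogen on an aromatic ring. Among the compounds with values here, no measured pair in this set shows what a change of this kind does in this assay, so there is no step to lean on. Given that, the step of a 1.1-fold higher number from compound 1 to compound 4 (0.04 log units; within the scatter) is expected to be small, not beyond the scatter in either direction. Compound 4 is therefore estimated at 2.5 mL/min/g in this assay, with a range of 1.2 mL/min/g to 5 mL/min/g to reflect both the repeat scatter and the absence of any guiding step.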

Compound 4, intrinsic clearance in a liver preparation (reported as CLH), per the amount of preparation that the assay uses: 1.9 mL/min/g
The estimate for compound 4 lay 1.3-fold (0.12 log units) above the measured number, within the range that was stated.
By their numbers in this assay, from the lowest: compounds 3, 2, 4 and 1 (each within the scatter of the next, the first and the last beyond it).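

Notes on the nitrogen position: in this assay, methyl in place of hydrogen on a nitrogen on an aromatic ring gives a 1.2-fold lower number from compound 1 to compound 4 (0.08 log units; within the scatter), the first step in this set that can be read at a single place. Going by these compounds alone, on the data at hand, compound 1 and compound 4 cannot be told apart, so with the rest of the structure held fixed, this position accepts methyl in place of hydrogen without a change beyond the scatter, something the earlier compounds, which differ in several respects at once, could not show. No supporting measurement bears on this result, and the step alone gives no explanation for it.

Still open, as far as these compounds go, is whether a larger group on the same nitrogen, such as ethyl, cyclopropyl or a longer chain ending in an amine or a carboxylic acid, would also stay within the scatter of compound 1 or would give a step beyond it. From the compounds shown here alone, this step also rests on a single pair built on the core of compound 1, so it remains unknown whether the same change would give a similar step with a different amide or a different substituent on the core.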